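This account rests on a few compounds, and the source may have more. Where it says the series, first, only, none or still open, it means among the compounds named here.

Of the compounds shown here, three have so far been measured in an assay on isolated protein for inhibition of coagulation factor X (Oryctolagus cuniculus), tested at 1 uM; a lower number here means less inhibition, a higher number more inhibition at the concentration tested (going by the name of the read-out). Compound 1 `O=C1[C@@H](NS(=O)(=O)c2cc3ncccc3s2)CCN1Cc1cc2c[nH]ccc-2n1` gives 61%, the highest of the three numbers shown, though compound 2 `CC(C)(C)c1ccc(S(=O)(=O)N[C@H]2CCN(Cc3cc4cc[nH]cc-4n3)C2=O)cc1` with 57% sits within the usual scatter of such measurements, so these two cannot be told apart. Compound 3 `O=C1[C@@H](NS(=O)(=O)c2ccc(-c3ccncc3)s2)CCN1Cc1cc2[nH]cccc-2n1` gives 35%, and its gap from compound 1 lies beyond the scatter. All three share one core and differ only in the group attached to the sulfonyl sulfur.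

Compound 4 `O=C1[C@@H](NS(=O)(=O)c2cc3c(Cl)nccc3s2)CCN1Cc1cc2c[nH]ccc-2n1` has not yet been measured. It differs from compound 1 in a single place: a group of 10 heavy atoms (7 carbon, 1 nitrogen, 1 sulfur, 1 chlorine; one five-membered aromatic ring with 1 hetero atom, one six-membered aromatic ring with 1 hetero atom) in place of a group of 9 heavy atoms (7 carbon, 1 nitrogen, 1 sulfur; one five-membered aromatic ring with 1 hetero atom, one six-membered aromatic ring with 1 hetero atom), on a sulfonyl sulfur. The rings stay the same; only a chlorine is new. Among the measured compounds shown here, no pair of measured compounds here is joined by one change, so no measured step sets a scale. With so small a change, the expected step from compound 1 to compound 4 is a number 5 percentage points higher from compound 1 to compound 4 (within the scatter), a small rise that need not clear the scatter. Compound 4 is expected to give 66% in this assay, within a range from 48% to 82%.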

Compound 4, a percentage reported as inhibition, at one concentration (the size of the read-out at that concentration, not a potency): 35%
Beside the measured number, compound 4's estimate is 31 percentage points above it, outside the stated range (below it).
By their numbers in this assay, from the lowest: compounds 3 and 4 (each within the scatter of the next); then compounds 2 and 1 (each within the scatter of the next).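

Among the compounds shown here, this is the first pair here joined by a single change, and it sets a scale: with the rings unchanged and only a chlorine new on the group on the sulfonyl sulfur, this assay shows a number 26 percentage points lower from compound 1 to compound 4 (beyond the scatter) for that one added atom. So this group does not accept every small addition, and even one extra heavy atom can move the number by more than the usual scatter. Nothing shown here gives a reason for this drop.

On these data alone, it remains open whether the fall belongs to chlorine itself or would follow any addition in its place, which a methyl group, a fluorine or a methoxy group there could help to settle. As far as these compounds go, whether a chlorine has the same effect with a different core also remains open.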